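The source may report more compounds than this note shows. Statements on the series, on what has been measured and on what is new or still open speak of the compounds shown alone.

Compound 1 `O=C(/C=C/c1cccnc1)NCCCCCc1ccc(S(=O)(=O)Nc2ccccc2)cc1`: 95.7 nM
Compound 2 `O=C(/C=C/c1cccnc1)NCCCCCCc1ccc(S(=O)(=O)Nc2ccccc2)cc1`: 36 nM
Compound 3 `Cc1ccc(NS(=O)(=O)c2cccc(CCCCCCNC(=O)/C=C/c3cccnc3)c2)cc1`: 1.97 nM

In a functional assay on MCF7 cells (Homo sapiens) for inhibition, read by CCK-8 assay, with a stated time of 72 h (a lower number here means a stronger inhibitor, a higher number a weaker inhibitor), compound 3 gives 1.97 nM, the lowest number of the three. Its gaps to compound 2 and to compound 1 both lie well beyond the usual scatter of repeat measurements, so compound 3 is the strongest inhibitor measured so far.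

The next compound, compound 4 `O=C(/C=C/c1cccnc1)NCCCCCCc1cccc(S(=O)(=O)Nc2ccc(F)cc2)c1`, keeps almost all of compound 3 and changes a single group: fluoro in place of methyl on an aromatic carbon. In words, fluoro takes the place of methyl on an aromatic carbon, turning the 4-methylphenyl group into a 4-fluorophenyl group.

Going by the values given here, no two measured compounds show what this swap does on its own, so the data offer no direct guide and any forecast is uncertain. One small group is exchanged for another, and the starting point is compound 3 at 1.97 nM. A shift within the scatter in this assay is therefore expected, leaning slightly towards a higher number, and the expected step is a 1.5-fold higher number from compound 3 to compound 4 (0.18 log units; within the scatter). A larger move in either direction cannot be ruled out. For compound 4 the estimated value is 3 nM, with an expected range of 0.8 nM to 12 nM.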

Compound 4, half-maximal inhibitory concentration: 0.91 nM
Compound 4: middle estimate off by 3.3-fold (0.52 log units), on the high side, within the range that was stated.
By their numbers in this assay, from the lowest: compound 4; then compound 3; then compound 2; then compound 1.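

In this assay, the 4-methylphenyl group of compound 3 proves not to be essential: the change to a 4-fluorophenyl group gives a 2.2-fold lower number from compound 3 to compound 4 (0.34 log units; beyond the scatter), a modest step but one that lies beyond the usual scatter. This is the only pair shown that differs in one place, so it gives the only direct reading of what a single exchange does here: on this aromatic carbon, para to a large group, fluoro not only replaces methyl without loss but gives a somewhat stronger inhibitor. No measurement accompanies these compounds that could explain the difference between the two groups, so the result records the size of the step and nothing about its origin.

From the compounds shown here alone, it remains open how far this position can be pushed, for example whether chloro, trifluoromethyl or an amine in the same place would give a lower or a higher number than fluoro. Going by these compounds, it is also open whether the same exchange of methyl for fluoro would give a similar step on a compound with a longer chain.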